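Swapping the Sulfonyl Substituent in a Macrocyclic Series

The source may report more compounds than this note shows. Statements on the series, on what has been measured and on what is new or still open speak of the compounds shown alone.

Measured compounds:
compound 1, `COc1ccc2c(OCC[C@@H]3NC(=O)N(C)CCCC/C=C\[C@@H]4C[C@@]4(C(=O)NS(=O)(=O)C4(F)CC4)NC3=O)cc(-c3nc(C(C)C)cs3)nc2c1Cl`: 51400 nM
compound 2, `COc1ccc2c(OCC[C@@H]3NC(=O)N(C)CCCC/C=C\[C@@H]4C[C@@]4(C(=O)NS(=O)(=O)N(C)C)NC3=O)cc(-c3nc(C(C)C)cs3)nc2c1Cl`: 47800 nM

In an ADME assay on cells (Homo sapiens) for activation (on this read-out higher numbers stand for lower toxicity in this test and lower numbers for higher toxicity in this test), compound 2 gives 47800 nM, and compound 1 gives 51400 nM; the two sit within the scatter of each other, as the step of a 1.1-fold lower number from compound 1 to compound 2 (0.03 log units; within the scatter) shows. Compound 3, `CCC1(S(=O)(=O)NC(=O)[C@@]23C[C@H]2/C=C\CCCCN(C)C(=O)N[C@@H](CCOc2cc(-c4nc(C(C)C)cs4)nc4c(Cl)c(OC)ccc24)C(=O)N3)CC1`, is not yet measured. It differs from compound 2 by 1-ethylcyclopropyl in place of dimethylamino on a sulfonyl sulfur. Going by the values given here, the only step that bears on this place, a 1.1-fold lower number from compound 1 to compound 2 (0.03 log units; within the scatter), stayed within the scatter, so no step beyond the scatter is expected in this assay, in either direction, for a 1.0-fold higher number from compound 2 to compound 3 (0.02 log units; within the scatter). Compound 3 is therefore estimated at 50000 nM, with a range from 25000 nM to 100000 nM.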

Compound 3, half-maximal cytotoxic concentration: 49300 nM
Estimate against measurement, compound 3: 1.0-fold (0.01 log units) above; the measured number falls inside the stated range.
By their numbers in this assay, from the lowest: compounds 2, 3 and 1 (each within the scatter of the next).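

Compound 3 adds a third group on the sulfonyl sulfur, and the read-out in this assay still does not separate it from the other two: the sulfonyl substituent shows a step (a 1.0-fold higher number from compound 2 to compound 3 (0.01 log units; within the scatter)). The change of ethyl in place of fluoro on a saturated ring carbon, with the ring itself kept, also stays small (a 1.0-fold lower number from compound 1 to compound 3 (0.02 log units; within the scatter)). Nothing measured here explains this.

Still open, from the compounds shown here alone, is whether a carboxylic acid, a primary amine or a longer alkyl chain on the sulfonyl sulfur would also stay within the scatter.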